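Swapping the neopentyl group for methoxycarbonyl in compound 1

The compounds below may be only part of what the source reports. "The series", "measured", "known", "first", "only" and "open" are said of these compounds alone.

Compound 1 `CC(C)c1cccc(C(C)C)c1NC(=O)NCC1(c2ccc(CC(C)(C)C)cc2)CCCC1` is the weakest of the three measured compounds in an assay on microsomes for inhibition of acyl-CoA:cholesterol acyltransferase (Oryctolagus cuniculus) (a lower number here means a stronger inhibitor, a higher number a weaker inhibitor), where compound 1 gives 159 nM. Compound 2 `COc1ccc(C2(CNC(=O)Nc3c(C(C)C)cccc3C(C)C)CCCC2)cc1` gives 31 nM in this assay, and compound 3 `CC(C)c1cccc(C(C)C)c1NC(=O)NCC1(c2ccc(OCc3ccccc3)cc2)CCCC1` gives 34 nM. Both neighbours differ from compound 1 only in the group on the outer aromatic ring: the step of a 5.1-fold lower number from compound 1 to compound 2 (0.71 log units; beyond the scatter) comes with methoxy in place of neopentyl on an aromatic carbon, and the step of a 4.7-fold lower number from compound 1 to compound 3 (0.67 log units; beyond the scatter) comes with benzyloxy in place of neopentyl on an aromatic carbon. Between those two, the step of a 1.1-fold higher number from compound 2 to compound 3 (0.04 log units; within the scatter) shows that phenyl in place of hydrogen on a saturated chain carbon bound to an oxygen on an aromatic ring made no difference beyond the scatter.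

Compound 4 `COC(=O)c1ccc(C2(CNC(=O)Nc3c(C(C)C)cccc3C(C)C)CCCC2)cc1` has not yet been measured. It differs from compound 1 as follows: methoxycarbonyl in place of neopentyl on an aromatic carbon. The two relevant steps both replaced neopentyl on the same aromatic carbon with an oxygen-bearing group and both lowered the number modestly. Methoxycarbonyl also carries oxygen, though as a different kind of group, so a somewhat smaller improvement is expected for compound 4, namely a 2.9-fold lower number from compound 1 to compound 4 (0.46 log units; beyond the scatter). The estimated value for compound 4 in this assay is 55 nM, with a range from 15 nM to 200 nM.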

Compound 4, half-maximal inhibitory concentration: 360 nM
The estimate for compound 4 lay 6.5-fold (0.82 log units) below the measured number, outside the stated range (above it).
By their numbers in this assay, from the lowest: compounds 2 and 3 (each within the scatter of the next); then compound 1; then compound 4.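

Methoxycarbonyl in place of neopentyl gives a 2.3-fold higher number from compound 1 to compound 4 (0.35 log units; beyond the scatter) in this assay, the opposite direction to the two earlier replacements of neopentyl, so the presence of oxygen in the new group does not by itself lower the number at this position. The comparison with the other oxygen-bearing groups is sharper still, with a 12-fold higher number from compound 2 to compound 4 (1.06 log units; beyond the scatter) and an 11-fold higher number from compound 3 to compound 4 (1.02 log units; beyond the scatter), which shows that this aromatic carbon separates methoxy and benzyloxy, each joined to the ring through oxygen, from methoxycarbonyl, joined through its carbonyl carbon, and that neopentyl, with no oxygen, falls between them. Nothing available here explains why methoxycarbonyl behaves so differently from methoxy and benzyloxy.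

The compounds shown leave open whether the weaker result belongs to the carbonyl link in general, which a carboxylic acid or a simple amide at the same carbon would help to test. They also leave open whether a small carbon-only group such as methyl or ethyl would fall nearer to neopentyl or to methoxy.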